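Adding a second methoxy to a naphthyl semicarbazone

The compounds below may be only part of what the source reports. "The series", "measured", "known", "first", "only" and "open" are said of these compounds alone.

Three semicarbazones built on the same core were tested in a functional assay on the whole organism (strain Swiss albino) with Mus musculus as the target, in the maximal electroshock model, with a stated time of 0.5 h; on this read-out higher numbers stand for an effect only at larger amounts of compound and lower numbers for an effect already at smaller amounts. Compound 1 `CN(C)c1ccc(/C=N/NC(=O)Nc2cccc3ccccc23)cc1`, which carries a dimethylamino group on the aromatic carbon, gives 100 mg/kg. Compound 2 `O=C(N/N=C/c1ccccc1)Nc1cccc2ccccc12`, with hydrogen in that position, gives 300 mg/kg, and compound 3 `COc1ccc(/C=N/NC(=O)Nc2cccc3ccccc23)cc1`, with methoxy there, gives 300 mg/kg. The steps of a 3.0-fold higher number from compound 1 to compound 2 (0.48 log units; beyond the scatter) and a 3.0-fold higher number from compound 1 to compound 3 (0.48 log units; beyond the scatter) both point the same way, whereas the step of no change at the digits printed from compound 2 to compound 3 (within the scatter) shows that swapping hydrogen for methoxy on this aromatic carbon left the read-out where it was. Compound 3 therefore stands level with compound 2 at the top of the three numbers, with compound 1 the only one set apart from it.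

Compound 4 `COc1ccc(/C=N/NC(=O)Nc2cccc3ccccc23)cc1OC` differs from compound 3 in one place: methoxy in place of hydrogen on an aromatic carbon. Among the measured compounds shown here, the only measured step of the same kind, no change at the digits printed from compound 2 to compound 3 (within the scatter), stayed within the scatter, so a change of similar size is expected here, with no shift beyond the scatter in either direction. Because of no change at the digits printed from compound 2 to compound 3 (within the scatter) the step of no change at the digits printed from compound 3 to compound 4 (within the scatter) is expected. Compound 4 is thus estimated to give 300 mg/kg in this assay, within a range from 150 mg/kg to 600 mg/kg.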

Compound 4, minimum effective dose: 100 mg/kg
The estimate for compound 4 lay 3.0-fold (0.48 log units) above the measured number, outside the stated range (below it).
By their numbers in this assay, from the lowest: compounds 1 and 4 (each within the scatter of the next); then compounds 2 and 3 (each within the scatter of the next).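

In this assay, the same swap of hydrogen for methoxy does not give the same outcome at every aromatic carbon: the earlier swap gave no change at the digits printed from compound 2 to compound 3 (within the scatter), while the swap at this position gave a 3.0-fold lower number from compound 3 to compound 4 (0.48 log units; beyond the scatter). The carbon that changes here is ortho to a methoxy group and meta to a large group, so the flat result of the earlier swap does not carry over to it, and the methoxy at this position goes with an effect at a smaller amount of compound. No measurement at hand explains why this carbon responds to methoxy when the earlier one did not.

The compounds shown leave open whether methoxy at this position would give a similar step on its own, with hydrogen in place of the other methoxy, as the two methoxy groups appear only together here. Going by these compounds, it also remains open whether a hydroxy group, a chlorine atom or a longer chain such as ethoxy on this same carbon would shift the minimum effective dose as methoxy does.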